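Swapping fluoro for trifluoromethoxy on compound 3

The source may hold more compounds than are shown below. What is called first, only, known or untested is meant among the compounds shown, and "the series" means these compounds.

compound 1 `Fc1ccccc1-c1ccc2[nH]c(C3=NOC4(CCCCC4)C3)nc2c1`: 79%
compound 2 `FC(F)(F)Oc1ccccc1-c1ccc2[nH]c(C3=NOC4(CCCCC4)C3)nc2c1`: 100%
compound 3 `Fc1ccccc1-c1cc(C(F)(F)F)c2[nH]c(C3=NOC4(CCCCC4)C3)nc2c1`: 71%

In an ADME assay on microsomes from liver (Homo sapiens) for metabolic stability, with a stated time of 10 min (a higher number here means that more of the compound is left, a lower number that less of the compound is left), compound 3 gives 71%. That reading lies within the scatter of compound 1, while compound 2 reads higher, a gap beyond the scatter.

The next compound to be tested is compound 4 `FC(F)(F)Oc1ccccc1-c1cc(C(F)(F)F)c2[nH]c(C3=NOC4(CCCCC4)C3)nc2c1`. It carries trifluoromethoxy in place of fluoro on an aromatic carbon, ortho to a large group, and otherwise matches compound 3: trifluoromethoxy in place of fluoro on an aromatic carbon.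

The same exchange has been measured once, without the trifluoromethyl group of compound 3, and it gave a number 21 percentage points higher from compound 1 to compound 2 (beyond the scatter). This is the most direct evidence, and it points to a modest rise. The other measured step, a number 8 percentage points lower from compound 1 to compound 3 (within the scatter), introduces that trifluoromethyl group and stays within the scatter. It therefore gives no reason to expect a different outcome here, although the data do not show whether the two changes simply add. Since the scale ends where nothing has been lost, the upper side of any estimate is limited.

A modest rise is expected, and the estimated step is a number 19 percentage points higher from compound 3 to compound 4 (beyond the scatter). For compound 4 the expected value in this assay is 90%, with an estimated range of 76% to 100%.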

Compound 4, percent of the compound remaining: 51%
Compound 4: the middle estimate sits 39 percentage points above what was measured; the whole stated range lies above it.
By their numbers in this assay, from the lowest: compound 4; then compounds 3 and 1 (each within the scatter of the next); then compound 2.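

In this assay, the exchange of fluoro for trifluoromethoxy, on an aromatic carbon ortho to a large group, turns out to have no fixed direction: on the core that carries the trifluoromethyl group it gives a number 20 percentage points lower from compound 3 to compound 4 (beyond the scatter), so the rise seen on the core without that group does not carry over: the same change on two cores in this assay, a number 21 percentage points higher (beyond the scatter) from compound 1 to compound 2 and a number 20 percentage points lower (beyond the scatter) from compound 3 to compound 4, 41 percentage points apart, beyond the scatter of two such steps

The trifluoromethyl group, for its part, showed no change beyond the scatter next to fluoro, but with trifluoromethoxy in place it gives a number 49 percentage points lower from compound 2 to compound 4 (beyond the scatter): the same change on two cores in this assay, a number 8 percentage points lower (within the scatter) from compound 1 to compound 3 and a number 49 percentage points lower (beyond the scatter) from compound 2 to compound 4, 41 percentage points apart, beyond the scatter of two such steps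

The two changes therefore do not add in these four compounds, and the outcome of either one can be read only together with what the other place carries.

The compounds shown leave open whether this dependence is particular to the pairing of trifluoromethoxy and trifluoromethyl, or would also appear with a methoxy group at the first place or a chlorine atom at the second. They also do not show which part of compound 4 is lost in the assay, so the reason for the interaction remains unknown.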